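Replacing an Arylamino Group with Dipropylamino

This account rests on a few compounds, and the source may have more. Where it says the series, first, only, none or still open, it means among the compounds named here.

Of the compounds shown here, two built on the same fused core have been tested in a functional assay on ECa-109 cells for inhibition, with ECa-109 cell line (Homo sapiens) as the target, read by sulforhodamine B assay; a lower number here means a stronger inhibitor, a higher number a weaker inhibitor. Compound 1, `O=C1C=C(Nc2ccc(I)cc2)C(=O)c2c1nc1n2[C@H]2OC[C@@H](O)[C@H]2OC1`, gives 2300 nM in this assay. Compound 2, `Cc1ccc(NC2=CC(=O)c3c(nc4n3[C@H]3OC[C@@H](O)[C@H]3OC4)C2=O)cc1C`, gives 4090 nM in this assay. Of these two numbers, that of compound 2 is the higher one, yet its gap to compound 1 falls within the usual scatter, so the two cannot be told apart. Compound 3, `CCCN(CCC)C1=CC(=O)c2c(nc3n2[C@H]2OC[C@@H](O)[C@H]2OC3)C1=O`, carries the change (dipropylamino in place of (3,4-dimethylphenyl)amino on a double-bonded ring carbon). For the measured compounds named here, no measured pair shows what swapping an aromatic amine for an aliphatic amine at this place does, so the direction rests on judgment alone. A moderate move toward a higher number is expected for the step of a 1.5-fold higher number from compound 2 to compound 3 (0.17 log units; within the scatter), with wide uncertainty in both directions. Compound 3 is therefore estimated at 6000 nM in this assay, with a range from 1500 nM to 25000 nM.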

Compound 3, half-maximal inhibitory concentration: > 16000 nM
Compound 3 was reported as a limit; the forecaster's own chance of this, stated with the estimate: 10%; at least 2.6-fold (0.42 log units) between middle value and limit.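

At this double-bonded ring carbon, putting dipropylamino in place of (3,4-dimethylphenyl)amino gives an at least 3.9-fold higher number from compound 2 to compound 3 (0.59 log units; beyond the scatter) in this assay. For the compounds shown here, compound 1 and compound 2 both carry an arylamino group and could not be told apart, so this is the first change at this position that moves the number beyond the scatter. Compound 3 stands at a limit of the assay rather than at a true number, so the full size of the step stays unknown: the limit of > 16000 nM in this assay, at which 1 of the 3 values shown sits.

The change removes the aromatic ring and the hydrogen-bond donor together, and the compounds shown cannot tell which of the two losses matters. A methyl(phenyl)amino group would keep the aromatic ring without the donor, while a cyclohexylamino group would keep the donor without the aromatic ring, so the two could pull these apart.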